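Aryl variation at the carbonyl carbon: compound 3 to compound 4

A few compounds are considered here, and "the series" means these few. Any claim that something is new, unique, unknown or untested is made for them only; others in the source may bear on it.

Measured compounds:
compound 1, `COc1cc(-c2cc(/C=C/C(=O)c3ccc(N)cc3)[nH]n2)cc(OC)c1OC`, in a functional assay on SNB-19 cells (Homo sapiens) for cytotoxicity, read by sulforhodamine B assay, with a stated time of 48 h, tested at 0.1 uM (on this read-out lower numbers stand for a stronger effect and higher numbers for a weaker effect at the one concentration tested), compound 1 gives 94%
compound 2, `COc1cc(-c2cc(/C=C/C(=O)c3ccc(Cl)c(Cl)c3)[nH]n2)cc(OC)c1OC`, in this assay compound 2 gives 92%
compound 3, `COc1ccc(C(=O)/C=C/c2cc(-c3cc(OC)c(OC)c(OC)c3)n[nH]2)cc1OC`, in this assay compound 3 gives 93%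

Compound 3 stands second highest of the three numbers in this assay. Its nearest neighbour is compound 1, with a number 1 percentage points lower from compound 1 to compound 3 (within the scatter); its furthest is compound 2, with a number 1 percentage points higher from compound 2 to compound 3 (within the scatter). All three numbers lie within the scatter of one another, so no order among them can be read.

Compound 4 is `COc1ccc(C(=O)/C=C/c2cc(-c3cc(OC)c(OC)c(OC)c3)n[nH]2)cc1`. The difference from compound 3 is hydrogen in place of methoxy on an aromatic carbon.

Every measured step in this set exchanges the aryl group on the carbonyl carbon while the rest of the shared core is kept: a number 2 percentage points lower from compound 1 to compound 2 (within the scatter), a number 1 percentage points lower from compound 1 to compound 3 (within the scatter) and a number 1 percentage points higher from compound 2 to compound 3 (within the scatter). None of these moved the read-out beyond the scatter, whether amino, chloro or methoxy groups were exchanged on that ring. The change to compound 4 is a smaller one of the same kind, a single methoxy leaving that ring. On this basis no step beyond the scatter is expected in this assay; the expected step is no change at the digits printed from compound 3 to compound 4 (within the scatter).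

Compound 4 is therefore estimated at 93%, with a range from 85% to 100%.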

Compound 4, a percentage reported as activity, at one concentration (the size of the read-out at that concentration, not a potency): 88%
For compound 4 the middle estimate is 5 percentage points above the measured one, within the range that was stated.
By their numbers in this assay, from the lowest: compounds 4, 2, 3 and 1 (each within the scatter of the next).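

With hydrogen in place of methoxy on an aromatic carbon, ortho to a methoxy group and meta to a large group, this assay gives a number 5 percentage points lower from compound 3 to compound 4 (within the scatter), so this first exchange that removes a group from the ring, rather than swapping one substituent pattern for another, also stays inside the usual spread of repeats. The wider comparisons agree, with a number 4 percentage points lower from compound 2 to compound 4 (within the scatter) and a number 6 percentage points lower from compound 1 to compound 4 (within the scatter), so the 4-methoxyphenyl group of compound 4 cannot be told apart from the aryl groups of compound 1, compound 2 or compound 3 at the one concentration tested. Nothing at hand offers an explanation for these read-outs at this position.

On these data alone, it remains open whether a carboxylic acid or a dimethylamino group on this ring, or a longer chain such as butoxy in place of the remaining methoxy, would give a step beyond the scatter in this assay. As far as these compounds go, the read-out is the size of the effect at a single concentration and not a potency, so whether these four compounds would separate at other concentrations also remains open.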